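The source may report more compounds than this note shows. Statements on the series, on what has been measured and on what is new or still open speak of the compounds shown alone.

The series keeps one core and varies the terminal aryl group. Compound 1 `CCOC(=O)CCCCCOc1cccc(CN(C(=O)c2ccc(-c3ccc4[nH]ccc4c3)cc2)C(C)C)c1` carries 1H-indol-5-yl, compound 2 `CCOC(=O)CCCCCOc1cccc(CN(C(=O)c2ccc(-c3cc(OC)ccc3F)cc2)C(C)C)c1` carries 2-fluoro-5-methoxyphenyl, and compound 3 `CCOC(=O)CCCCCOc1cccc(CN(C(=O)c2ccc(-c3cc(C(F)(F)F)cc(C(F)(F)F)c3)cc2)C(C)C)c1` carries two trifluoromethyl groups. In an ADME assay on Raji cells (Homo sapiens) for cytotoxicity, read by CellTiter-Glo and resazurin assay, with a stated time of 72 h (on this read-out higher numbers stand for an effect only at larger amounts of compound and lower numbers for an effect already at smaller amounts), compound 1 gives only a limit of the assay, > 26000 nM. In this assay compound 2 likewise gives only a limit, > 26000 nM. In this assay compound 3 also gives only a limit, > 26000 nM. For the measured compounds named here, the one step between measured compounds, a step that the two limits leave unreadable from compound 1 to compound 2, has a limit at each end and cannot be sized. The only regularity in the set is the limit of > 26000 nM in this assay, at which 3 of the 3 values shown sit, so compound 3 stands at that limit together with the other two and cannot be ranked against them.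

Compound 4 `CCOC(=O)CCCCCOc1cccc(CN(C(=O)c2ccc(-c3cccc(C(F)(F)F)c3)cc2)C(C)C)c1` differs from compound 3 by hydrogen in place of trifluoromethyl on an aromatic carbon. Going by the values given here, no measured step bears on this change in a readable way: the single step, a step that the two limits leave unreadable from compound 1 to compound 2, is unreadable, and all values in this assay sit at the limit, (the limit of > 26000 nM in this assay, at which 3 of the 3 values shown sit). Compound 4 is therefore expected to stay at the limit, the expected step that the limit leaves unreadable from compound 3 to compound 4 being none beyond the scatter. The estimate for compound 4 in this assay is 40000 nM, with a range from 20000 nM to 100000 nM.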

Compound 4, half-maximal effective concentration: > 26000 nM
Compound 4 was reported as a limit; the forecaster's own chance of this, stated with the estimate: 85%; the middle value does not contradict the limit.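

In this assay compound 4 gives only a limit, > 26000 nM. Its steps to compound 1, compound 2 and compound 3 cannot be read, as every value sits at the same limit: the limit of > 26000 nM in this assay, at which 4 of the 4 values shown sit.

The compounds shown leave open whether any terminal aryl group gives a numerical value in this assay, and how these groups would rank there.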